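Adding a Second Fluorine and Tolerance in Vero Cells

The source may hold more compounds than are shown below. What is called first, only, known or untested is meant among the compounds shown, and "the series" means these compounds.

Compound 1 `C[C@]1(CN2CCc3nc(-c4ccccc4)ncc3C2)Cn2cc([N+](=O)[O-])nc2O1` was entered in an ADME assay on Vero cells (Chlorocebus sabaeus) for cytotoxicity, read by MTT assay, with a stated time of 72 h (a higher number here means that more compound is tolerated, a lower number that less compound is tolerated), but gives "not determined" (no result reported), so no number exists for it. Compound 2 `C[C@]1(CN2CCc3nc(-c4ccc(F)cc4)oc3C2)Cn2cc([N+](=O)[O-])nc2O1` gives > 32 ug/mL in this assay, which is a limit of the assay rather than a measured number. Compound 2 therefore stands at the edge of what the measurement can show, a point described by the limit of > 32 ug/mL in this assay, at which 1 of the 2 values shown sits, and there is no second number to set beside it.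

Compound 3 `C[C@]1(CN2CCc3nc(-c4ccc(F)c(F)c4)oc3C2)Cn2cc([N+](=O)[O-])nc2O1` is still to be measured. It differs from compound 2 by fluoro in place of hydrogen on an aromatic carbon. Going by the values given here, no measured step of this kind is available, so the step in this assay is expected to be a step that the limit leaves unreadable from compound 2 to compound 3, within the usual scatter and in no particular direction. Compound 3 is expected to give 40 ug/mL in this assay, within a range from 16 ug/mL to 100 ug/mL, and a reading that again stops at the limit is the likelier outcome.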

Compound 3, half-maximal cytotoxic concentration: > 32 ug/mL
Compound 3 gave a limit, no number; the forecaster's own chance of this, stated with the estimate: 75%; the middle value does not contradict the limit.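

Going by these compounds alone, compound 2 and compound 3 each end at a limit of this assay rather than a number, and no step between them can be read. Still open, on these data alone, is how much of either compound the cells tolerate, and whether 4-fluorophenyl and 3,4-difluorophenyl differ at all.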